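Aryl ether variation and rat microsomal half-life

The source may report more compounds than this note shows. Statements on the series, on what has been measured and on what is new or still open speak of the compounds shown alone.

Compound 3 `Cc1nc(C)c([C@H](OC(C)(C)C)C(=O)O)c(N2CCC(C)(C)CC2)c1-c1ccc(OC2COCC2c2ccc(F)cc2)cc1` sits at the limit of an ADME assay on microsomes from liver (Rattus norvegicus) for metabolic stability, read by LC-MS, tested at 0.5 uM; on this read-out higher numbers stand for a longer-lived compound and lower numbers for a shorter-lived compound: in this assay compound 3 gives > 2 h, which is a limit and not a number. Compound 1 `COc1ccc(CCOc2ccc(-c3c(C)nc(C)c([C@H](OC(C)(C)C)C(=O)O)c3N3CCC(C)(C)CC3)cc2)cc1` also gives > 2 h, a limit. Compound 2 `COc1cccc(CCOc2ccc(-c3c(C)nc(C)c([C@H](OC(C)(C)C)C(=O)O)c3N3CCC(C)(C)CC3)cc2)c1` likewise gives > 2 h, again a limit. The steps among these three, a step that the two limits leave unreadable from compound 1 to compound 2, a step that the two limits leave unreadable from compound 1 to compound 3 and a step that the two limits leave unreadable from compound 2 to compound 3, are therefore unreadable in size, as the limit of > 2 h in this assay, at which 3 of the 3 values shown sit, shows. Compound 4 `Cc1nc(CCOc2ccc(-c3c(C)nc(C)c([C@H](OC(C)(C)C)C(=O)O)c3N3CCC(C)(C)CC3)cc2)cs1` carries 2-(2-methyl-1,3-thiazol-4-yl)ethyl in place of 4-(4-fluorophenyl)oxolan-3-yl on an oxygen on an aromatic ring. For the measured compounds named here, no measured step gives a readable size or direction for this change, so the expected step that the limit leaves unreadable from compound 3 to compound 4 rests on the shared limit alone and is expected to stay small. Compound 4 is estimated at 2.5 h, with a range from 1 h to 5 h, and will most likely again be reported only as a limit.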

Compound 4, half-life: 1.75 h
Beside the measured number, compound 4's estimate is 1.4-fold (0.15 log units) above it; low and high end bracket the measured number.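

Compound 4 is the only one of these aryl ethers that gives a number rather than a limit in this assay, so this position on the oxygen now has readable floors: an at least 1.1-fold lower number from compound 3 to compound 4 (0.05 log units; that floor lies within the scatter), an at least 1.1-fold lower number from compound 2 to compound 4 (0.05 log units; that floor lies within the scatter) and an at least 1.1-fold lower number from compound 1 to compound 4 (0.05 log units; that floor lies within the scatter). Each floor stays within the scatter, so no real loss of half-life is established for the 2-(2-methyl-1,3-thiazol-4-yl)ethyl group. The full size of these steps is unknown because the other compounds stop at a limit: the limit of > 2 h in this assay, at which 3 of the 4 values shown sit.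

On these data alone, whether a pyridyl group in place of 2-methyl-1,3-thiazol-4-yl, or a longer chain on the same oxygen, would move the half-life beyond the scatter stays open.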